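This account rests on a few compounds, and the source may have more. Where it says the series, first, only, none or still open, it means among the compounds named here.

Measured so far:
compound 1 `COc1ccc(C(=O)/C=C/c2cccc(F)c2)c2c1C=CC(C)(C)O2` — > 10000 nM
compound 2 `COc1ccc(C(=O)/C=C/c2ccc(N(c3ccccc3)c3ccccc3)cc2)c2c1C=CC(C)(C)O2` — > 10000 nM
compound 3 `COc1ccc(C(=O)/C=C/c2ccc3ccccc3n2)c2c1C=CC(C)(C)O2` — 3790 nM

In a functional assay on HT-29 cells (Homo sapiens) for antiproliferative activity, read by MTT assay, with a stated time of 24 h (on this read-out lower numbers stand for stronger inhibition and higher numbers for weaker inhibition), compound 1 gives only a limit, > 10000 nM, and no number. Compound 2 likewise reaches only a limit in this assay, > 10000 nM. Among the compounds with values here, compound 3 is the one member with a numerical value in this assay, 3790 nM. Within the data shown here, compound 1 therefore stands at the limit of > 10000 nM in this assay, at which 2 of the 3 values shown sit, together with compound 2, and no step between measured compounds that differ in one place is available; nothing can be said about how far compound 1 lies beyond that limit.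

Compound 4 `COc1ccc(C(=O)/C=C/c2ccc(Cl)c(Cl)c2)c2c1C=CC(C)(C)O2` differs from compound 1 in one place: 3,4-dichlorophenyl in place of 3-fluorophenyl on a double-bonded chain carbon bound to a double-bonded chain carbon. With compound 1 at a limit, the size of this step cannot be anchored to a measured change. The expectation is a step toward stronger inhibition, an at least 1.4-fold lower number from compound 1 to compound 4 (0.15 log units; that floor lies within the scatter), small enough that it may not clear the scatter, with a real chance that compound 4 again returns only a limit in this assay. Compound 4 is estimated at 7000 nM, within 2000 nM to 25000 nM.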

Compound 4, half-maximal inhibitory concentration: 7580 nM
Compound 4: the middle estimate sits 1.1-fold (0.03 log units) below what was measured, within the range that was stated.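

In this assay, 3,4-dichlorophenyl in place of 3-fluorophenyl on a double-bonded chain carbon bound to a double-bonded chain carbon gives an at least 1.3-fold lower number from compound 1 to compound 4 (0.12 log units; that floor lies within the scatter). Compound 1 gives > 10000 nM, which is a limit and not a number, so this step has a floor but no measured size. This is the first single-place change in the series to give a numerical value from a limit, yet the floor does not establish a real gain, and the limit remains common in the set: the limit of > 10000 nM in this assay, at which 2 of the 4 values shown sit.

Still open, on these data alone, is whether both chlorine atoms are needed for a numerical value or a phenyl ring carrying a single chlorine would suffice. The compounds shown also leave open how a carboxylic acid or a dimethylamino group would read at this place.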